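Phenyl to 2,4-dichlorophenyl on compound 1

The compounds below may be only part of what the source reports. "The series", "measured", "known", "first", "only" and "open" are said of these compounds alone.

In a functional assay on SF-295 cells (Homo sapiens) for inhibition, read by sulforhodamine B assay, with a stated time of 48 h (a higher number here means a weaker inhibitor of growth, a lower number a stronger inhibitor of growth), compound 1 (`O=C(Cc1csc2nc(-c3ccc(Br)cc3)cn12)N/N=C/c1ccccc1`) gives 12000 nM, compound 2 (`O=C(Cc1csc2nc(-c3ccc(Br)cc3)cn12)N/N=C/c1ccc(O)cc1`) gives 12000 nM and compound 3 (`COc1cccc(OC)c1/C=N/NC(=O)Cc1csc2nc(-c3ccc(Br)cc3)cn12`) gives 12300 nM. Compound 1 is thus level with compound 2 and within the scatter of compound 3. Compound 4 (`O=C(Cc1csc2nc(-c3ccc(Br)cc3)cn12)N/N=C/c1ccc(Cl)cc1Cl`) differs from compound 1 at one place, on a carbon with a double bond to nitrogen: 2,4-dichlorophenyl in place of phenyl on a carbon with a double bond to nitrogen. Two measured steps alter the aromatic ring at that place: no change at the digits printed from compound 1 to compound 2 (within the scatter) and a 1.0-fold higher number from compound 1 to compound 3 (0.01 log units; within the scatter). Neither introduces chlorine, so the precedent is only indirect. The expected change is a 1.2-fold lower number from compound 1 to compound 4 (0.08 log units; within the scatter), with nothing beyond the scatter anticipated. Compound 4 is expected at 10000 nM, with an estimated range of 4500 nM to 20000 nM.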

Compound 4, concentration for 50% growth inhibition: 34700 nM
Compound 4: the middle estimate sits 3.5-fold (0.54 log units) below what was measured, outside the stated range (above it).
By their numbers in this assay, from the lowest: compounds 1, 2 and 3 (each within the scatter of the next); then compound 4.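

In this assay the aromatic ring on a carbon with a double bond to nitrogen proves able to move the number, which compound 1, compound 2 and compound 3 did not show. The 2,4-dichlorophenyl change gives a 2.9-fold higher number from compound 1 to compound 4 (0.46 log units; beyond the scatter) and likewise a 2.9-fold higher number from compound 2 to compound 4 (0.46 log units; beyond the scatter) and a 2.8-fold higher number from compound 3 to compound 4 (0.45 log units; beyond the scatter) in the same direction, toward weaker growth inhibition, so the modest loss holds against all three rings. No measurement at hand accounts for this loss.

Going by these compounds, whether a single chlorine gives the same loss stays open. So does the effect of an amine or a carboxylic acid on the phenyl ring.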